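The source may hold more compounds than are shown below. What is called first, only, known or untested is meant among the compounds shown, and "the series" means these compounds.

Compound 1 `O=C(C1CCCO1)N1CC(c2nc(-c3cccc(Cl)c3)no2)C1` and compound 2 `O=C(c1ccc(F)cc1)N1CC(c2nc(-c3cccc(Cl)c3)no2)C1` share one core and differ only in the group on the carbonyl carbon. In an assay on HEK293 cells for positive allosteric modulation of metabotropic glutamate receptor 5 (Homo sapiens), read by FLIPR (a higher number here means that more compound is needed for the effect, a lower number that less compound is needed), compound 1 gives > 10000 nM, which is a limit of the assay and not a number. In this assay compound 2 likewise gives > 10000 nM, again a limit. The step from oxolan-2-yl to 4-fluorophenyl, a step that the two limits leave unreadable from compound 1 to compound 2, is therefore of unreadable size. Both measurements rest at the same limit (the limit of > 10000 nM in this assay, at which 2 of the 2 values shown sit), so compound 2 stands without a fixed number; only a bound on its potency is known. Compound 3 `O=C(c1cccc(F)c1)N1CC(c2nc(-c3cccc(Cl)c3)no2)C1` differs from compound 2 by 3-fluorophenyl in place of 4-fluorophenyl on a carbonyl carbon. For the measured compounds named here, no measured step bears directly on this change; the one step recorded is unreadable, and neither acyl group so far brought the value under the limit. For the move from compound 2 to compound 3 one expects a step that the limit leaves unreadable from compound 2 to compound 3, nothing beyond the scatter. Compound 3 is estimated at 15000 nM, within 3000 nM to 60000 nM, most likely again only a limit.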

Compound 3, half-maximal effective concentration: > 10000 nM
Compound 3 was reported as a limit; the forecaster's own chance of this, stated with the estimate: 80%; the middle value is on the limit's open side.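

Compound 3, like compound 1 and compound 2, rests at a limit in this assay, so no step among these compounds can be read: the limit of > 10000 nM in this assay, at which 3 of the 3 values shown sit.

The compounds shown leave open how 3-fluorophenyl, 4-fluorophenyl and oxolan-2-yl on the carbonyl carbon truly compare, and whether any group there gives a fixed number.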